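A few compounds are considered here, and "the series" means these few. Any claim that something is new, unique, unknown or untested is made for them only; others in the source may bear on it.

Compound 1, `O=C(Nc1ccc(Br)cc1)N1CCC[C@H]1c1nc(-c2ccccc2)no1`: in an ADME assay on MCF-10A cells (Homo sapiens) for inhibition, with a stated time of 48 h (a higher number here means a weaker inhibitor, a lower number a stronger inhibitor), compound 1 gives only a limit, > 50000 nM.
Compound 2, `N#Cc1ccc(NC(=O)N2CCC[C@H]2c2nc(-c3ccccc3)no2)cc1`: in this assay compound 2 gives only a limit, > 50000 nM.
Compound 3, `O=C(Nc1ccc(Cl)cc1)N1CCC[C@H]1c1nc(-c2ccccc2Br)no1`: in this assay compound 3 gives only a limit, > 50000 nM.

Compound 3 thus stands where every measured compound stands: at the limit of this assay, with no number of its own, only the statement that inhibition was not reached within the tested range. The same holds for compound 1 and compound 2, so there is no measured value in this series to compare against.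

The change from compound 3 to compound 4, `O=C(Nc1ccc(Cl)cc1)N1CCC[C@H]1c1nc(-c2ccc(Cl)cc2)no1`, is 4-chlorophenyl in place of 2-bromophenyl on an aromatic carbon. Going by the values given here, the only measured step, a step that the two limits leave unreadable from compound 1 to compound 2, runs from one limit to another and its size cannot be read, so it gives neither a direction nor a magnitude to carry over. What the measurements do show is the limit of > 50000 nM in this assay, at which 3 of the 3 values shown sit, and nothing in the shared core or in the groups that have been varied has moved any compound off that limit.

Compound 4 is therefore expected to remain at the limit as well, with an estimated value of 100000 nM, between 30000 nM and 300000 nM. The expected step is a step that the limit leaves unreadable from compound 3 to compound 4, which is no change beyond the scatter.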

Compound 4, half-maximal inhibitory concentration: > 50000 nM
Compound 4 ended at the assay's limit; the forecaster's own chance of this, stated with the estimate: 85%; the middle value lies beyond the limit too.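

The step from compound 3 to compound 4, 4-chlorophenyl in place of 2-bromophenyl, cannot be read, because both results are limits of this assay rather than numbers: the limit of > 50000 nM in this assay, at which 4 of the 4 values shown sit. The compounds shown leave open whether any change to the shared core or its groups would give a measurable half-maximal inhibitory concentration on these cells.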